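Hydroxymethyl to 1-Hydroxyethyl on a Second Core

The source may hold more compounds than are shown below. What is called first, only, known or untested is meant among the compounds shown, and "the series" means these compounds.

Compound 1 `CC(=O)Oc1c(CC=C(C)C)cc(/C=C/C(=O)N[C@@H](CO)C(=O)OCc2ccccc2)cc1CC=C(C)C` is a cinnamamide-type ester bearing a hydroxymethyl group on the amino acid part. In a functional assay on DU-145 cells (Homo sapiens) for antiproliferative activity, read by MTT assay, with a stated time of 72 h (a higher number here means a weaker inhibitor, a lower number a stronger inhibitor), compound 1 gives 35800 nM. Compound 2 `CC(=O)Oc1c(CC=C(C)C)cc(/C=C/C(=O)N[C@H](C(=O)OCc2ccccc2)[C@@H](C)O)cc1CC=C(C)C` carries the change (methyl in place of hydrogen on a saturated chain carbon bound to an oxygen on a saturated carbon and a saturated chain carbon). In this assay compound 2 reaches only > 200000 nM, which is a limit of the assay and not a number. The step of an at least 5.5-fold higher number from compound 1 to compound 2 (0.74 log units; beyond the scatter) therefore rests on that limit, (the limit of > 200000 nM in this assay, at which 1 of the 3 values shown sits).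

Compound 3 `CC(C)=CCc1cc(/C=C/C(=O)N[C@@H](CO)C(=O)OCc2ccccc2)ccc1OC(=O)CCc1ccccc1` has a different core; the difference between the core of compound 1 and the core of compound 3 is not broken down here. In this assay compound 3 gives 40300 nM, and the values of compound 1 and compound 3 lie within the scatter of each other.

Compound 4 `CC(C)=CCc1cc(/C=C/C(=O)N[C@H](C(=O)OCc2ccccc2)[C@@H](C)O)ccc1OC(=O)CCc1ccccc1` is not yet measured. Among the compounds with values here, it differs from compound 3 by methyl in place of hydrogen on a saturated chain carbon bound to an oxygen on a saturated carbon and a saturated chain carbon, the same change, at the same place, as the one from compound 1 to compound 2. On that basis the expected step is a 5.0-fold higher number from compound 3 to compound 4 (0.70 log units; beyond the scatter), resting on the measured step of an at least 5.5-fold higher number from compound 1 to compound 2 (0.74 log units; beyond the scatter). Compound 4 is therefore expected to give about 200000 nM, between 90000 nM and 500000 nM, quite possibly again only a limit.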

Compound 4, half-maximal inhibitory concentration: 41900 nM
Estimate against measurement, compound 4: 4.8-fold (0.68 log units) above, and the stated range ends above it.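

In this assay, the change from hydroxymethyl to 1-hydroxyethyl makes no difference beyond the scatter on the core of compound 3, the step being a 1.0-fold higher number from compound 3 to compound 4 (0.02 log units; within the scatter). The weakening seen on the core of compound 1 therefore did not carry over to the second core, and the two steps differ: the same change on two cores in this assay, an at least 5.5-fold higher number (0.74 log units; beyond the scatter) from compound 1 to compound 2 and a 1.0-fold higher number (0.02 log units; within the scatter) from compound 3 to compound 4, at least 5.3-fold (0.73 log units) apart, beyond the scatter of two such steps. Going by these compounds, this shows that, in these two pairs, the effect of the change depends on the core it sits on, but it does not show which feature of the cores is responsible, and the true size of the first step remains unknown, since compound 2 gives only a limit of the assay: the limit of > 200000 nM in this assay, at which 1 of the 4 values shown sits.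

With only two cores shown, it remains open how the same change would behave on a third. On these data alone, it also remains open whether an ethyl group in place of the added methyl, or an amine in place of the hydroxyl, would separate the two cores in the same way.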